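Swapping butyl for methoxy on a weak inhibitor

A few compounds are considered here, and "the series" means these few. Any claim that something is new, unique, unknown or untested is made for them only; others in the source may bear on it.

compound 1 `CCCCc1ccc(-c2c(C)[nH]c(=O)n2C)cc1` gives 10700 nM
compound 2 `CCCCc1ccc(-c2c(CC)[nH]c(=O)n2C)cc1` gives 13900 nM
compound 3 `CCCCc1ccc(-c2c(C)[nH]c(=O)n2-c2ccccc2)cc1` gives 16600 nM

In a functional assay on brain (Rattus norvegicus, strain Wistar) for inhibition (a higher number here means a weaker inhibitor, a lower number a stronger inhibitor), compound 1 stands level with the other two compounds, as both of its measured steps stay inside the normal spread of repeat measurements. Methyl in place of hydrogen on the saturated chain carbon gives a 1.3-fold higher number from compound 1 to compound 2 (0.11 log units; within the scatter). Phenyl in place of methyl on the aromatic nitrogen gives a 1.6-fold higher number from compound 1 to compound 3 (0.19 log units; within the scatter).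

The next compound, compound 4 `COc1ccc(-c2c(C)[nH]c(=O)n2C)cc1`, keeps the core of compound 1 but carries methoxy in place of butyl on an aromatic carbon. Neither measured step touches this place, and every measured compound carries butyl there. The two small steps show only that this assay changed little under edits elsewhere on the core, so they cannot be carried over to this change. The data therefore fix neither the size nor the direction of the step. A cautious guess is a moderate move towards a higher number, with wide margins on both sides. The expected step is a 2.1-fold higher number from compound 1 to compound 4 (0.31 log units; beyond the scatter). For compound 4 the estimated value is 22000 nM, with an expected range from 7000 nM to 70000 nM.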

Compound 4, half-maximal inhibitory concentration: 147000 nM
The estimate for compound 4 lay 6.7-fold (0.82 log units) below the measured number; the whole stated range lies below it.
By their numbers in this assay, from the lowest: compounds 1, 2 and 3 (each within the scatter of the next); then compound 4.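

In this assay, methoxy in place of butyl on this aromatic carbon gives a 14-fold higher number from compound 1 to compound 4 (1.14 log units; beyond the scatter), the only listed step that lies beyond the scatter. The edits at the two other places on the core stayed within the scatter, so this position is the one among those shown where a change clearly alters the number, and butyl here goes with much stronger inhibition than methoxy. The swap changes two things at once, since butyl has 4 heavy atoms, all carbon, and no hydrogen-bond acceptor, whereas methoxy has 2 heavy atoms, one of them oxygen, and 1 hydrogen-bond acceptor; no measurement shown explains why the number rises so sharply.

The compounds shown leave open whether chain length or the oxygen matters more here: a butoxy group would keep a longer chain along with the oxygen, while a plain methyl or ethyl group would give a short chain with no oxygen. They also leave open whether a longer chain, such as hexyl, would lower the number further or raise it again.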